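Dropping the Chloro from a Benzothiazole Aminopyrimidine

The source may hold more compounds than are shown below. What is called first, only, known or untested is meant among the compounds shown, and "the series" means these compounds.

Measured compounds in an ADME assay on cells (Homo sapiens) for cytotoxicity, read by polymerase chain reaction, with a stated time of 3 days; a higher number here means that more compound is tolerated, a lower number that less compound is tolerated:
compound 1 `Nc1nc(Cl)c(-c2cccs2)c(N[C@@H]2C[C@H](CO)[C@@H](O)[C@H]2O)n1`, reported only as a limit of the assay, > 25000 nM
compound 2 `Nc1nc(Cl)c(-c2nc3ccccc3s2)c(N[C@@H]2C[C@H](CO)[C@@H](O)[C@H]2O)n1`, 14000 nM
compound 3 `CN(C)c1ccc2nc(-c3c(Cl)nc(N)nc3N[C@@H]3C[C@H](CO)[C@@H](O)[C@H]3O)sc2c1`, reported only as a limit of the assay, > 25000 nM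

Compound 2 is the only one of the three with an actual number in this assay; the other two sit at the limit of > 25000 nM in this assay, at which 2 of the 3 values shown sit. Compound 4 `Nc1ncc(-c2nc3ccccc3s2)c(N[C@@H]2C[C@H](CO)[C@@H](O)[C@H]2O)n1` differs from compound 2 in a single place: hydrogen in place of chloro on an aromatic carbon. Neither measured step touches this position. The two steps that do exist, an at least 1.7-fold lower number from compound 1 to compound 2 (0.25 log units; that floor lies within the scatter) and an at least 1.7-fold higher number from compound 2 to compound 3 (0.25 log units; that floor lies within the scatter), each run to or from a limit and each has a floor that lies within the scatter, so they fix neither the size nor the direction of a change at this core. With all three measured values at or near the limit in this assay, compound 4 is expected to land in the same region, and a step beyond the scatter is not expected in either direction. The estimate for compound 4 in this assay is 20000 nM, with a range from 7000 nM to 60000 nM. That estimate means an expected step of a 1.4-fold higher number from compound 2 to compound 4 (0.15 log units; within the scatter), and it is expected that the assay may again report only a limit.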

Compound 4, half-maximal cytotoxic concentration: > 25000 nM
Compound 4: no number, only a limit (the forecaster's own chance of this, stated with the estimate: 45%); at least 1.2-fold (0.09 log units) between middle value and limit.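

In this assay, among the compounds shown here, hydrogen in place of chloro gives an at least 1.7-fold higher number from compound 2 to compound 4 (0.25 log units; that floor lies within the scatter), the first step that touches this position, the aromatic carbon ortho to the 1,3-benzothiazol-2-yl group. It shows that the 1,3-benzothiazol-2-yl compound does not need the chloro here to stay at the top of the measurable range, and that losing this one atom brings no sign of a lower number. The true size of the change stays hidden, and the series now offers even less room to tell compounds apart: the limit of > 25000 nM in this assay, at which 3 of the 4 values shown sit.

The compounds shown leave open how far past the limit compound 4 lies, and whether the same change would read alike on the thiophen-2-yl compound 1 or the dimethylamino compound 3, both of which already sit at the limit with the chloro in place. They also leave open what a different group at this carbon, such as a methyl, a methoxy or an amine, would do, since chloro and hydrogen are the only two seen here.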